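The source may hold more compounds than are shown below. What is called first, only, known or untested is meant among the compounds shown, and "the series" means these compounds.

Of the compounds shown here, three have been measured in a functional assay on HL-60 cells (Homo sapiens) for antiproliferative activity, read by sulforhodamine B assay, with a stated time of 72 h; on this read-out higher numbers stand for weaker inhibition and lower numbers for stronger inhibition. Compound 1 (`Cc1cc(C)nc(NS(=O)(=O)c2ccc(Nc3nncc4ccccc34)cc2)n1`) gives 9.5 nM, compound 2 (`C(=C/c1ccccc1)\C(=N\Nc1nncc2ccccc12)c1ccccc1`) gives 4.7 nM, and compound 3 (`O=S(=O)(Nc1ncccn1)c1ccc(Nc2nncc3ccccc23)cc1`) gives 67 nM. That is the highest of the three numbers, and its gaps to both other compounds lie beyond the scatter. Compound 4 (`O=S(=O)(Nc1nccs1)c1ccc(Nc2nncc3ccccc23)cc1`) has not yet been measured. It differs from compound 3 in one place, on a sulfonamide nitrogen: 1,3-thiazol-2-yl in place of pyrimidin-2-yl on a sulfonamide nitrogen. Going by the values given here, only one measured step bears on this position. Replacing 4,6-dimethylpyrimidin-2-yl with pyrimidin-2-yl on a sulfonamide nitrogen gave a 7.1-fold higher number from compound 1 to compound 3 (0.85 log units; beyond the scatter), a modest change beyond the scatter. Among the compounds with values here, no measured compound carries 1,3-thiazol-2-yl, so the data fix no direction for the new change, and that single step offers only a rough guide to its size. A small shift towards stronger inhibition is tentatively expected, amounting to a 1.5-fold lower number from compound 3 to compound 4 (0.17 log units; within the scatter), which would stay within the scatter. For compound 4 the estimated value is 45 nM, with an expected range from 12 nM to 170 nM.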

Compound 4, half-maximal inhibitory concentration: 77 nM
Estimate against measurement, compound 4: 1.7-fold (0.23 log units) below; the range from low to high includes it.
By their numbers in this assay, from the lowest: compound 2; then compound 1; then compounds 3 and 4 (each within the scatter of the next).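

In this assay, exchanging a six-membered aromatic ring for a five-membered one on the sulfonamide nitrogen gives a 1.1-fold higher number from compound 3 to compound 4 (0.06 log units; within the scatter), so this position tolerates pyrimidin-2-yl and 1,3-thiazol-2-yl alike. The 4,6-dimethylpyrimidin-2-yl group now stands apart from two other groups rather than one: replacing it with 1,3-thiazol-2-yl gives an 8.1-fold higher number from compound 1 to compound 4 (0.91 log units; beyond the scatter), and replacing it with pyrimidin-2-yl gives a 7.1-fold higher number from compound 1 to compound 3 (0.85 log units; beyond the scatter). No measurement at hand explains why these groups compare as they do.

The compounds shown leave open whether the two methyl groups alone account for the gap, which a single methyl on the pyrimidin-2-yl ring would help to settle. They also leave open whether methyl groups on the 1,3-thiazol-2-yl ring, or a phenyl ring on the sulfonamide nitrogen, would match compound 1.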